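The compounds below may be only part of what the source reports. "The series", "measured", "known", "first", "only" and "open" are said of these compounds alone.

Working notes, cytotoxicity series. Compound 1 `C1=C(CCCCc2ccccc2)COc2ccccc21` in an ADME assay on HeLa cells (Homo sapiens) for cytotoxicity, read by XTT assay (a lower number here means that less compound is tolerated, a higher number that more compound is tolerated), gives 100000 nM. Compound 2 `C1=C(CCCCCc2ccccc2)COc2ccccc21` differs by benzyl in place of phenyl on a saturated chain carbon, four bonds along the chain from a double-bonded ring carbon; in this assay compound 2 gives 100000 nM, and the step is no change at the digits printed from compound 1 to compound 2 (within the scatter). Compound 3 `c1ccc(CCCCC2COc3ccccc3C2)cc1` sits on another core; the difference between the two cores is not broken down here. In this assay compound 3 gives 100000 nM, level with compounds 1 and 2. Compound 4 `c1ccc(CCCCCC2COc3ccccc3C2)cc1` is not yet measured and carries benzyl in place of phenyl on a saturated chain carbon, four bonds along the chain from a saturated ring carbon. This is the same kind of change as from compound 1 to compound 2, but the place differs: there four bonds along the chain from a double-bonded ring carbon, here four bonds along the chain from a saturated ring carbon. In this assay a step of no change at the digits printed from compound 3 to compound 4 (within the scatter) is expected, because no change at the digits printed from compound 1 to compound 2 (within the scatter) shows no movement for the same kind of change. Compound 4 is estimated at 100000 nM, expected between 50000 nM and 200000 nM.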

Compound 4, half-maximal cytotoxic concentration: 200000 nM
Estimate against measurement, compound 4: 2.0-fold (0.30 log units) below; measured number inside the range.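

In this assay benzyl in place of phenyl gives a 2.0-fold higher number from compound 3 to compound 4 (0.30 log units; within the scatter), and the same change on the core of compound 1 gives no change at the digits printed from compound 1 to compound 2 (within the scatter). Set side by side, the two steps do not separate: the same change on two cores in this assay, no change at the digits printed (within the scatter) from compound 1 to compound 2 and a 2.0-fold higher number (0.30 log units; within the scatter) from compound 3 to compound 4, 2.0-fold (0.30 log units) apart, within the scatter of two such steps. Going by these compounds alone, the change therefore reads alike on these two cores, but neither step lies beyond the scatter, so this shows only that it leaves the number in place on both, not that a real shift would carry over, and two pairs set no rule for the series.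

Still open, as far as these compounds go, is whether an amine or a carboxylic acid in place of the phenyl, or a longer chain, would move the number in this assay on either core.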